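Working notes: replacing the aryl group of compound 2

The compounds below may be only part of what the source reports. "The series", "measured", "known", "first", "only" and "open" are said of these compounds alone.

Values in a functional assay on U-937 cells (Homo sapiens) for cytotoxicity, read by MTT assay, with a stated time of 24 h; a higher number here means a weaker inhibitor, a lower number a stronger inhibitor:
compound 1 `CCCCCCCCCCn1cc(Cn2nc(N)c3c(C(F)(F)F)cc(-c4ccccc4)nc32)nn1`: 27.1 ug/mL
compound 2 `Nc1nn(Cc2cn(-c3ccc(F)c(Cl)c3)nn2)c2nc(-c3ccccc3)cc(C(F)(F)F)c12`: 99.1 ug/mL
compound 3 `Nc1nn(Cc2cn(-c3ccc(O)c([N+](=O)[O-])c3)nn2)c2nc(-c3ccccc3)cc(C(F)(F)F)c12`: 41.3 ug/mL

Compound 2 gives the highest number of the three, 99.1 ug/mL, which makes it the weakest here. The measured steps to it are a 3.7-fold higher number from compound 1 to compound 2 (0.56 log units; beyond the scatter) and a 2.4-fold lower number from compound 2 to compound 3 (0.38 log units; beyond the scatter).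

Compound 4 `Cc1c(Br)cccc1-n1cc(Cn2nc(N)c3c(C(F)(F)F)cc(-c4ccccc4)nc32)nn1` is still unmeasured. Its change from compound 2 is 3-bromo-2-methylphenyl in place of 3-chloro-4-fluorophenyl on an aromatic nitrogen. For the measured compounds named here, it carries 3-bromo-2-methylphenyl in place of 3-chloro-4-fluorophenyl on an aromatic nitrogen, and no measured compound carries this group.

Going by the values given here, the closest evidence is the only measured exchange of one substituted phenyl for another at this place, a 2.4-fold lower number from compound 2 to compound 3 (0.38 log units; beyond the scatter). The steps from decyl are less direct, and a 1.5-fold higher number from compound 1 to compound 3 (0.18 log units; within the scatter) is the smaller of them. One exchange gives a weak guide to direction. A step no larger than that modest one is therefore expected in this assay, towards a lower number if it shows at all, and it may stay within the scatter. The expected change is a 1.4-fold lower number from compound 2 to compound 4 (0.15 log units; within the scatter). For compound 4 the estimated value is 70 ug/mL, with an expected range of 32 ug/mL to 150 ug/mL.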

Compound 4, half-maximal inhibitory concentration: 97.2 ug/mL
Compound 4: middle estimate off by 1.4-fold (0.14 log units), on the low side; measured number inside the range.
By their numbers in this assay, from the lowest: compounds 1 and 3 (each within the scatter of the next); then compounds 4 and 2 (each within the scatter of the next).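

In this assay, a 1.0-fold lower number from compound 2 to compound 4 (0.01 log units; within the scatter), so 3-chloro-4-fluorophenyl and 3-bromo-2-methylphenyl cannot be told apart at this position, although they differ in halogen and in the methyl group. The earlier single exchange of one substituted phenyl for another therefore does not hold as a general trend: a 2.4-fold higher number from compound 3 to compound 4 (0.37 log units; beyond the scatter), and a 3.6-fold higher number from compound 1 to compound 4 (0.55 log units; beyond the scatter), which leaves the two halogen-bearing phenyl compounds, 2 and 4, together apart from compounds 1 and 3. No measured evidence bears on why these groups separate in this way.

From the compounds shown here alone, it remains open how a phenyl carrying an amine or a carboxylic acid would read at this position. The effect of a chain shorter than decyl on the aromatic nitrogen is also unresolved.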